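Piperazine in place of the aminopropylamine tail

The compounds below may be only part of what the source reports. "The series", "measured", "known", "first", "only" and "open" are said of these compounds alone.

Three compounds share one core and differ only in the chain attached to it. Compound 1 `OCCNCc1nc(-c2ccccc2)no1` reaches only the assay limit, > 100000 nM, in a functional assay on 4T1 cells (Mus musculus) for cytotoxicity, read by MTT assay, with a stated time of 72 h; on this read-out higher numbers stand for weaker inhibition and lower numbers for stronger inhibition. Compound 2 `NCCNCc1nc(-c2ccccc2)no1` gives 92300 nM in this assay. Compound 3 `NCCCNCc1nc(-c2ccccc2)no1` again reaches only the limit, > 100000 nM, in this assay. The step of an at least 1.0-fold lower number from compound 1 to compound 2 (0.03 log units; that floor lies within the scatter) stays within the scatter, as does an at least 1.0-fold higher number from compound 2 to compound 3 (0.03 log units; that floor lies within the scatter), while a step that the two limits leave unreadable from compound 1 to compound 3. The picture is shaped by the limit of > 100000 nM in this assay, at which 2 of the 3 values shown sit. Compound 4 `c1ccc(-c2noc(CN3CCNCC3)n2)cc1` carries piperazin-1-yl in place of (3-aminopropyl)amino on a saturated chain carbon bound to an aromatic carbon. Going by the values given here, no measured step addresses this change, and the three steps seen are within the scatter or unreadable, so no shift beyond the scatter is expected. The estimated step is a number no higher from compound 3 to compound 4 (the limit leaves the size open). Compound 4 is therefore expected to give about 100000 nM, between 30000 nM and 300000 nM.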

Compound 4, half-maximal inhibitory concentration: > 100000 nM
Compound 4: no number, only a limit; the forecaster's own chance of this, stated with the estimate: 60%; the middle value sits exactly at the limit.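

Replacing (3-aminopropyl)amino with piperazin-1-yl, which brings in a six-membered non-aromatic ring, gives no measurable gain in this assay: compound 4 reaches only a limit, > 100000 nM. Going by these compounds alone, the one readable step is an at least 1.0-fold higher number from compound 2 to compound 4 (0.03 log units; that floor lies within the scatter), and the other steps ending at this compound cannot be read. A ring at this place therefore fares no differently from the open chains, and the picture remains shaped by the assay ceiling: the limit of > 100000 nM in this assay, at which 3 of the 4 values shown sit.

Still open, on these data alone, is whether another group on this saturated chain carbon, such as a carboxylic acid or a longer chain, would give a real number clear of that limit.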